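Series notes: chain extension at the aromatic-ring oxygen

The source may report more compounds than this note shows. Statements on the series, on what has been measured and on what is new or still open speak of the compounds shown alone.

Measured so far in a functional assay on PANC-1 cells (Homo sapiens) for inhibition, read by MTT assay, with a stated time of 24 h, tested at 10 uM; on this read-out lower numbers stand for less inhibition and higher numbers for more inhibition at the one concentration tested (going by the name of the read-out):
compound 1 `CCOc1cc(=O)n(CCCO)c2c1CC(CC=C(C)C)C(C)(C)C2`, 16.6%
compound 2 `COc1ccc(OCCCOc2cc(=O)n(CCCO)c3c2CC(CC=C(C)C)C(C)(C)C3)cc1`, 4.1%
compound 3 `CCOc1cc(=O)n(CCCO)c2c1CC(C/C=C(\C)CCC=C(C)C)C(C)(C)C2`, 0.8%

Compound 3 stands lowest of the three numbers; its nearest neighbour is compound 2, within the scatter, and compound 1 lies beyond the scatter above it. Compound 4 `CC(C)=CCC/C(C)=C/CC1Cc2c(OCCCNC(=O)c3cccs3)cc(=O)n(CCCO)c2CC1(C)C` differs from compound 3 by (((thiophen-2-yl)carbonyl)amino)methyl in place of hydrogen on a saturated chain carbon, two bonds along the chain from an oxygen on an aromatic ring. Going by the values given here, the only measured step at that place is a number 12.5 percentage points lower from compound 1 to compound 2 (beyond the scatter), a drop; the other step, a number 15.8 percentage points lower from compound 1 to compound 3 (beyond the scatter), concerns a different site and already sits in compound 3. With compound 3 near the floor of the read-out, little room remains: the expected step for compound 4 in this assay is a number 0.8 percentage points lower from compound 3 to compound 4 (within the scatter), not beyond the scatter. Compound 4 is therefore estimated at 0%, in the range -12% to 12%.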

Compound 4, a percentage reported as inhibition, at one concentration (the size of the read-out at that concentration, not a potency): 11.5%
For compound 4 the middle estimate is 11.5 percentage points below the measured one; the measured number falls inside the stated range.
By their numbers in this assay, from the lowest: compounds 3, 2, 4 and 1 (each within the scatter of the next, the first and the last beyond it).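

In this assay, a substituent on the saturated chain carbon, two bonds along the chain from the oxygen on the aromatic ring, does not always lower the number: (((thiophen-2-yl)carbonyl)amino)methyl gives a number 10.7 percentage points higher from compound 3 to compound 4 (beyond the scatter) and so runs opposite to (4-methoxyphenoxy)methyl, which gives a number 12.5 percentage points lower from compound 1 to compound 2 (beyond the scatter) on the other side chain. The two steps differ in both entering group and background, so neither alone accounts for the reversal. Nothing available explains the rise.

Open, from the compounds shown here alone, is whether (((thiophen-2-yl)carbonyl)amino)methyl raises the number on compound 1 as well. Also open, going by these compounds, is how an amine or a carboxylic acid at this place would read.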